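The source may report more compounds than this note shows. Statements on the series, on what has been measured and on what is new or still open speak of the compounds shown alone.

Measured so far: compound 1 `COc1ccc2c(C(=O)c3cc(OC)c(OC)c(OC)c3)c(CCCCCO)[nH]c2c1` with 57.3 nM; compound 2 `CCOC(=O)Cc1[nH]c2cc(OC)ccc2c1C(=O)c1cc(OC)c(OC)c(OC)c1` with 3.9 nM; compound 3 `COc1ccc2c(C)cc(N/N=C/c3ccccc3O)nc2c1` with 2000 nM.

In a functional assay on KB cells (Homo sapiens) for inhibition (on this read-out lower numbers stand for stronger inhibition and higher numbers for weaker inhibition), compound 2 gives the lowest number of the three. Compound 1 stands one measured step above it, and compound 3, built on a different core, gives a far higher number; for that pair only the two values are known. For the measured compounds named here, the single measured step that bears on the change at hand is a 15-fold lower number from compound 1 to compound 2 (1.17 log units; beyond the scatter), which puts an ethoxycarbonyl ahead of a 4-hydroxybutyl at the same place. Compound 4 `CCCCCc1[nH]c2cc(OC)ccc2c1C(=O)c1cc(OC)c(OC)c(OC)c1` carries butyl in place of ethoxycarbonyl on a saturated chain carbon bound to an aromatic carbon. The ester that set compound 2 apart is removed and nothing carrying an acceptor takes its place, so the step from compound 2 to compound 4 is expected to run towards higher numbers, roughly a 10-fold higher number from compound 2 to compound 4 (1.01 log units; beyond the scatter). Going by the values given here, the margin is kept wide because the one relevant step a 15-fold lower number from compound 1 to compound 2 (1.17 log units; beyond the scatter) compares the ester against a hydroxyalkyl rather than a plain alkyl. Compound 4 is expected at 40 nM, within 10 nM to 200 nM.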

Compound 4, half-maximal inhibitory concentration: 38 nM
The estimate for compound 4 lay 1.1-fold (0.02 log units) above the measured number, and the stated range covers the measured number.
By their numbers in this assay, from the lowest: compound 2; then compounds 4 and 1 (each within the scatter of the next); then compound 3.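

In this assay, hydrogen in place of hydroxy on the chain leaves no readable difference, with a 1.5-fold lower number from compound 1 to compound 4 (0.18 log units; within the scatter). The ethoxycarbonyl step seen earlier against the hydroxylated chain now recurs against a plain alkyl chain, with a 9.7-fold higher number from compound 2 to compound 4 (0.99 log units; beyond the scatter), so the low number of compound 2 stands out against both chains at this saturated chain carbon bound to an aromatic carbon. No measurement on the series accounts for this gap.

Going by these compounds, whether the gap follows the whole ethoxycarbonyl or only its carbonyl remains open, and a carboxylic acid, a primary amide or a ketone on the same carbon would separate these cases. Also open, on these data alone, is how far the chain result extends, since an amine at the chain end or a much shorter alkyl chain could behave differently from the two chains compared here.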